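This account rests on a few compounds, and the source may have more. Where it says the series, first, only, none or still open, it means among the compounds named here.

Of the compounds shown here, two have been tested in a functional assay on COLO 205 cells (Homo sapiens) for inhibition, read by sulforhodamine B assay, tested at 10 uM; on this read-out lower numbers stand for less inhibition of growth and higher numbers for more inhibition of growth at the one concentration tested. Compound 1 `CC(=O)N1N=C(c2ccc(OCc3cn(Cc4ccc([N+](=O)[O-])cc4)nn3)cc2)CC1c1ccccc1` gives 18% in this assay. Compound 2 `COc1cc(C2CC(c3ccc(Br)cc3)=NN2C(C)=O)ccc1OCc1cn(Cc2ccc([N+](=O)[O-])cc2)nn1` gives 26% in this assay. The two numbers lie within the usual scatter of each other, so on the numbers shown compound 2 does not stand apart from compound 1, and no trend can be read from this pair.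

The step from compound 2 to compound 3 `COc1cc(C2CC(c3cc(OC)c(OC)c(OC)c3)=NN2C(C)=O)ccc1OCc1cn(Cc2ccc([N+](=O)[O-])cc2)nn1` changes one position: 3,4,5-trimethoxyphenyl in place of 4-bromophenyl on a carbon with a double bond to nitrogen. Among the measured compounds shown here, no measured pair shows the effect of such a swap, so there is no step to lean on; the expectation rests on the shared core and on the values of compound 1 and compound 2 alone.

From compound 2 to compound 3 a modest rise is expected, a step of a number 9 percentage points higher from compound 2 to compound 3 (within the scatter) in this assay, without confidence that it exceeds the scatter. For compound 3 the expected result in this assay is 35%, with a likely range from 10% to 65%.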

Compound 3, percent growth inhibition at one concentration: 60%
Compound 3: middle estimate off by 25 percentage points, on the low side; the measured number falls inside the stated range.
By their numbers in this assay, from the lowest: compounds 1 and 2 (each within the scatter of the next); then compound 3.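

In this assay putting 3,4,5-trimethoxyphenyl in place of 4-bromophenyl gives a step of a number 34 percentage points higher from compound 2 to compound 3 (beyond the scatter) and so marks this position, on a carbon with a double bond to nitrogen, as one where a single change can move the read-out clearly; compound 1 and compound 2 differ in more than one place and could not show this. The two groups share one six-membered aromatic ring of carbon only and differ in what that ring carries: the entering group has 12 heavy atoms and 3 hydrogen-bond acceptors, while the leaving group has 7 heavy atoms and no hydrogen-bond acceptors. Which of these differences matters cannot be told from one pair, and no measurement shown here explains the rise.

The compounds shown leave open whether all three methoxy groups are needed or whether a 4-methoxyphenyl group would read the same. On these data alone, it also remains open how an amine or a carboxylic acid on this ring would read, and whether the same swap would give a similar step on the core of compound 1.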